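Dichlorophenyl Replaces Hydroxyphenyl on the Saturated Ring Carbon

This account rests on a few compounds, and the source may have more. Where it says the series, first, only, none or still open, it means among the compounds named here.

Compound 3 `COc1cc(/C=C/C(=O)C2=C(/C=C/c3ccc(O)c(OC)c3)NC(=S)NC2c2ccccc2O)ccc1O` gives 25% in a functional assay, with a stated time of 20 min, tested at 2 uM (on this read-out lower numbers stand for a weaker effect and higher numbers for a stronger effect at the one concentration tested), the second highest of the three numbers shown. Compound 1 `COc1cc(/C=C/C(=O)C2=C(/C=C/c3ccc(O)c(OC)c3)NC(=O)NC2c2ccccc2O)ccc1O` gives 33.6% and compound 2 `COc1cc(/C=C/C(=O)C2=C(/C=C/c3ccc(O)c(OC)c3)NC(=S)NC2c2ccc(C)cc2)ccc1O` gives 15.5%; both lie within the scatter of compound 3. Compound 4 `COc1cc(/C=C/C(=O)C2=C(/C=C/c3ccc(O)c(OC)c3)NC(=S)NC2c2c(Cl)cccc2Cl)ccc1O` differs from compound 3 by 2,6-dichlorophenyl in place of 2-hydroxyphenyl on a saturated ring carbon. For the measured compounds named here, the one measured step at the same saturated ring carbon, a number 9.5 percentage points higher from compound 2 to compound 3 (within the scatter), stayed within the scatter, so an aryl swap at that place has not so far moved this assay beyond its noise. Compound 4 is therefore expected to show no step beyond the scatter, a number 5 percentage points lower from compound 3 to compound 4 (within the scatter), leaning slightly toward compound 2 because compound 2, which carries 4-methylphenyl there, gave 15.5%. The estimate for compound 4 is 20%, between 8% and 34%.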

Compound 4, a percentage reported as activity, at one concentration (the size of the read-out at that concentration, not a potency): 17.7%
Compound 4: middle estimate off by 2.3 percentage points, on the high side; the measured number falls inside the stated range.
By their numbers in this assay, from the lowest: compounds 2, 4, 3 and 1 (each within the scatter of the next, the first and the last beyond it).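

In this assay the swap to 2,6-dichlorophenyl on the saturated ring carbon stays within the scatter in both readings, with a number 7.3 percentage points lower from compound 3 to compound 4 (within the scatter) and a number 2.2 percentage points higher from compound 2 to compound 4 (within the scatter). Three aryl groups at this place now fall within the scatter along these steps, so the hydrogen-bond donor and acceptor of 2-hydroxyphenyl are not shown to matter in this read-out, and neither are the two chlorine atoms. No evidence on the reason for these small steps is at hand. Going by these compounds, whether an aminophenyl, a carboxyphenyl or a cyclohexyl group at this carbon would move the number beyond the scatter stays open.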